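Ester to Amide on a Shared Core: Clearance Outlook

The compounds below may be only part of what the source reports. "The series", "measured", "known", "first", "only" and "open" are said of these compounds alone.

Compound 1, `CC(c1c(F)cc2ncccc2c1F)n1cnc2ncc(-c3ccncc3)nc21`: 14 uL/min
Compound 2, `COC(=O)c1ccc(-c2cnc3ncn(C(C)c4cc5cccnc5cc4F)c3n2)cc1F`: 73 uL/min
Compound 3, `COC(=O)c1ccc(-c2cnc3ncn(C(C)c4c(F)cc5ncccc5c4F)c3n2)cc1F`: 290 uL/min

These numbers come from an ADME assay on microsomes from liver (Homo sapiens) for metabolic stability, read by LC-MS, using NADPH, with stated times of 5 min and 30 min, tested at 1 uM; a higher number here means faster removal of the compound, a lower number slower removal. Compound 2 stands second highest of the three: compound 3 sits above it by a 4.0-fold higher number from compound 2 to compound 3 (0.60 log units; beyond the scatter), while compound 1 lies below it by a gap beyond the scatter. Compound 4, `CC(c1cc2cccnc2cc1F)n1cnc2ncc(-c3ccc(C(N)=O)c(F)c3)nc21`, differs from compound 2 in one place: amino in place of methoxy on a carbonyl carbon. Neither measured step bears directly on this change. The step of a 21-fold higher number from compound 1 to compound 3 (1.32 log units; beyond the scatter) swaps the whole aryl group, and a 4.0-fold higher number from compound 2 to compound 3 (0.60 log units; beyond the scatter) adds a fluoro elsewhere, so no guide exists for exchanging methoxy for amino on the carbonyl carbon. Without one, a modest step toward a lower number is expected, a 1.8-fold lower number from compound 2 to compound 4 (0.26 log units; within the scatter). Compound 4 is therefore estimated at 40 uL/min, within 15 uL/min to 110 uL/min.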

Compound 4, intrinsic clearance in a liver preparation (reported as CLH), per the amount of preparation that the assay uses: 14 uL/min
Compound 4: the middle estimate sits 2.9-fold (0.46 log units) above what was measured; measured number outside the range, below it.
By their numbers in this assay, from the lowest: compounds 1 and 4 (each within the scatter of the next); then compound 2; then compound 3.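

Putting amino in place of methoxy on the carbonyl carbon gives a 5.2-fold lower number from compound 2 to compound 4 (0.72 log units; beyond the scatter) in this assay and is the first change shown at this position alone. The earlier steps shown here swapped the whole aryl group or added a fluoro, whereas this one shows that methoxycarbonyl to carbamoyl by itself moves the number beyond the scatter. No measurement here explains the drop.

On these data alone, whether the same change acts alike with the extra fluoro of compound 3 stays open. So does what a carboxylic acid or a methylamino group would give on this carbonyl carbon.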